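Ester side chain on the nitrogen: shortening the ester

The compounds below may be only part of what the source reports. "The series", "measured", "known", "first", "only" and "open" are said of these compounds alone.

Compound 1 `COc1ccc(-c2cc3c(OC)cc(OC)cc3n(C)c2=O)cc1` carries a methyl on the aromatic nitrogen of the shared core, and in a functional assay on T47D cells (Homo sapiens) for cytotoxicity, read by colorimetric assay and MTT assay (on this read-out lower numbers stand for stronger inhibition and higher numbers for weaker inhibition), compound 1 gives 10000 nM. Compound 2 `COc1ccc(-c2cc3c(OC)cc(OC)cc3n(CC(=O)OCc3ccccc3)c2=O)cc1` replaces that methyl hydrogen with benzyloxycarbonyl; in this assay compound 2 gives 10000 nM, so the step of no change at the digits printed from compound 1 to compound 2 (within the scatter) leaves the read-out where it was. On the numbers shown compound 2 therefore stands level with compound 1, and neither can be called stronger or weaker than the other.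

Compound 3 `COC(=O)CCn1c(=O)c(-c2ccc(OC)cc2)cc2c(OC)cc(OC)cc21` is the next member, differing from compound 2 as follows: (methoxycarbonyl)methyl in place of benzyloxycarbonyl on a saturated chain carbon bound to an aromatic nitrogen. Among the compounds with values here, the only measured step touching this position, no change at the digits printed from compound 1 to compound 2 (within the scatter), showed that adding benzyloxycarbonyl on that chain carbon changed nothing within the scatter; no measured pair tells what a smaller ester group on the same carbon does. With compound 1 and compound 2 sitting at the same weak level, the expectation for compound 3 is no step beyond the scatter, no change at the digits printed from compound 2 to compound 3 (within the scatter). Compound 3 is thus estimated at 10000 nM, with a range from 5000 nM to 20000 nM.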

Compound 3, half-maximal inhibitory concentration: 10000 nM
Beside the measured number, compound 3's estimate shows no gap at the digits printed; low and high end bracket the measured number.
By their numbers in this assay, from the lowest: compounds 1, 2 and 3 (each within the scatter of the next).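

In this assay the new result adds a much smaller ester at this place: replacing benzyloxycarbonyl, with its six-membered aromatic ring of carbon only and 10 heavy atoms, by (methoxycarbonyl)methyl, with no ring and 5 heavy atoms, gives no change at the digits printed from compound 2 to compound 3 (within the scatter) in the read-out, so removing the ring and the other heavy atoms leaves it level. Measured directly against the hydrogen of compound 1, the same group gives no change at the digits printed from compound 1 to compound 3 (within the scatter) on a saturated chain carbon bound to an aromatic nitrogen, so neither the benzyl ester nor the methyl ester separates from the unsubstituted case in these compounds. No measurement available here accounts for this flat result.

Still open, going by these compounds, is whether a carboxylic acid in place of the ester, an amine on the chain, or a longer chain on the aromatic nitrogen would part from this common level. With all three compounds level, the series gives no direction for this side chain, and nothing shown tells whether a change elsewhere on the shared core would read differently.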